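A few compounds are considered here, and "the series" means these few. Any claim that something is new, unique, unknown or untested is made for them only; others in the source may bear on it.

Compound 2, with the structure `COc1ccc(-c2cnc(NC(=O)C3CCOCC3)n2C)cc1`, is the starting point of this step. In a toxicity assay on THP-1 cells (Homo sapiens) for inhibition (on this read-out higher numbers stand for lower toxicity in this test and lower numbers for higher toxicity in this test), compound 2 gives > 100000 nM, which is a limit of the assay and not a measured number. For the measured compounds named here, its only measured neighbour is compound 1, with the structure `COc1ccc(-c2cnc(NC(=O)c3cccc(OC)c3)n2C)cc1`. In this assay compound 1 gives > 100000 nM, again a limit rather than a number. The change between them, oxan-4-yl in place of 3-methoxyphenyl on a carbonyl carbon, therefore produced a step that the two limits leave unreadable from compound 1 to compound 2, and the only firm thing on record is the limit of > 100000 nM in this assay, at which 2 of the 2 values shown sit.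

Compound 3, with the structure `CCCC(=O)Nc1ncc(-c2ccc(OC)cc2)n1C`, is not yet measured. It differs from compound 2 by propyl in place of oxan-4-yl on a carbonyl carbon. Going by the values given here, no measured step touches a propyl group, so there is nothing that points to a readable shift in either direction in this assay. The expectation is therefore that the step of a number no higher from compound 2 to compound 3 (the limit leaves the size open) stays within scatter and that compound 3 also reaches the limit. Compound 3 is expected to give about 100000 nM, within a range from 30000 nM to 300000 nM.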

Compound 3, half-maximal cytotoxic concentration: > 100000 nM
Compound 3 gave a limit, no number (the forecaster's own chance of this, stated with the estimate: 80%); the middle value sits exactly at the limit.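

Compound 1, compound 2 and compound 3 all end in limits rather than numbers, so none of the steps among them can be read in this assay. The compounds shown leave open how far apart the three really lie, and whether any group on the carbonyl carbon would give a measurable value: the limit of > 100000 nM in this assay, at which 3 of the 3 values shown sit.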